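The source may hold more compounds than are shown below. What is called first, only, known or untested is meant among the compounds shown, and "the series" means these compounds.

Of the compounds shown here, three of a shared core have been measured in an ADME assay on MT4 cells (Homo sapiens) for cytotoxicity, read by MTT assay, with a stated time of 4 days; a lower number here means that less compound is tolerated, a higher number that more compound is tolerated. Compound 1 `O=C(COc1cccc2ccccc12)N/N=C/c1c(O)ccc2ccccc12` gives 2.12 ug/mL in this assay. Compound 2 `Cc1ccc(/C=N/NC(=O)COc2cccc3ccccc23)cc1` gives 83.9 ug/mL. Compound 3 `C/C(=N\NC(=O)COc1cccc2ccccc12)c1ccc(O)cc1` gives 68.8 ug/mL, which is the second highest of the three numbers. Compound 3 sits within the scatter of compound 2, while it is far beyond the scatter from compound 1, which tolerates much less compound.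

The step in question leads from compound 3 to compound 4 `C/C(=N\NC(=O)COc1cccc2ccccc12)c1ccc(Br)cc1`. The difference between the two structures is bromo in place of hydroxy on an aromatic carbon. For the measured compounds named here, no measured pair shows this same change, so its effect has to be judged from what the three numbers allow. Compound 2, which carries no hydroxy group at the same kind of position, gives 83.9 ug/mL, a number that stands within the scatter of compound 3. That suggests the hydroxy group alone does not set the number, and its replacement need not move it far.

The expected step of a 1.5-fold lower number from compound 3 to compound 4 (0.18 log units; within the scatter) is small and toward a lower number, probably not beyond the scatter. Compound 4 is estimated to give 45 ug/mL, with a range from 15 ug/mL to 100 ug/mL.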

Compound 4, half-maximal cytotoxic concentration: 77.6 ug/mL
For compound 4 the middle estimate is 1.7-fold (0.24 log units) below the measured one; low and high end bracket the measured number.
By their numbers in this assay, from the lowest: compound 1; then compounds 3, 4 and 2 (each within the scatter of the next).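

Putting bromo in place of hydroxy on an aromatic carbon, para to a large group, gives a 1.1-fold higher number from compound 3 to compound 4 (0.05 log units; within the scatter) in this assay. For the compounds shown here, this is the first direct look at this position, since the earlier compounds offered no pair that differs in one place: hydroxy, with its hydrogen-bond donor and acceptor, gives way to bromo, with neither, and the number stays within the scatter, so for this pair the tolerated concentration does not depend on that donor and acceptor. Nothing measured here explains why this exchange is so well tolerated.

Going by these compounds alone, only two groups have been compared at this position, so it remains open whether an amine, a carboxylic acid or a longer chain on the same carbon would also stay within the scatter. This single step also cannot be carried over to compound 1, which gives 2.12 ug/mL and differs from compound 3 in more than one place, so what sets its number apart remains unresolved.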